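A few compounds are considered here, and "the series" means these few. Any claim that something is new, unique, unknown or untested is made for them only; others in the source may bear on it.

Measured so far:
- Compound 1, `CCCCCC(O)/C=C/[C@@H]1[C@@H](C/C=C\CCCC(=O)O)[C@@H]2C[C@H]1OC(=O)O2`: 0.23 nM
- Compound 2, `CCCCCC(O)/C=C/[C@@H]1[C@@H](C/C=C\CCCC(N)=O)[C@@H]2C[C@H]1OC(=O)O2`: 58 nM
- Compound 3, `CCCCCC(O)/C=C/[C@@H]1[C@@H](C/C=C\CCCC(=O)NC(C)C)[C@@H]2C[C@H]1OC(=O)O2`: 324 nM

All three share one core and differ only in the group at the end of the chain. In an assay on thoracic aorta with thromboxane A2 receptor (Rattus norvegicus) as the target (on this read-out higher numbers stand for an effect only at larger amounts of compound and lower numbers for an effect already at smaller amounts), compound 1 gives 0.23 nM, compound 2 gives 58 nM, and compound 3 gives 324 nM. Compound 3 thus stands at the highest number of the three: it is a 5.6-fold higher number from compound 2 to compound 3 (0.75 log units; beyond the scatter) and a 1400-fold higher number from compound 1 to compound 3 (3.15 log units; beyond the scatter), so the change from the acid of compound 1 to the two amides raised the number each time.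

Compound 4, `CCCCCC(O)/C=C/[C@@H]1[C@@H](C/C=C\CCCCO)[C@@H]2C[C@H]1OC(=O)O2`, continues this series with hydroxymethyl in place of isopropylcarbamoyl on a saturated chain carbon, three bonds along the chain from a double-bonded chain carbon. Among the compounds with values here, no measured step replaces an amide or an acid with an alcohol, so the three steps from compound 1 bear on it only indirectly: they show that the acid of compound 1 gives the lowest number and that both changes away from it, a 250-fold higher number from compound 1 to compound 2 (2.40 log units; beyond the scatter) and a 1400-fold higher number from compound 1 to compound 3 (3.15 log units; beyond the scatter), were large. A hydroxymethyl group is again a departure from the acid, so a number similar to or somewhat higher than that of compound 3 is expected, with the step of a 1.5-fold higher number from compound 3 to compound 4 (0.19 log units; within the scatter) expected to stay within the usual scatter. For compound 4 the estimate in this assay is 500 nM, with a range from 60 nM to 5000 nM.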

Compound 4, half-maximal effective concentration: 1 nM
Beside the measured number, compound 4's estimate is 500-fold (2.70 log units) above it; the whole stated range lies above it.
By their numbers in this assay, from the lowest: compound 1; then compound 4; then compound 2; then compound 3.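

In this assay, replacing the amide end groups with hydroxymethyl brings the number down sharply, with a 320-fold lower number from compound 3 to compound 4 (2.51 log units; beyond the scatter) and a 58-fold lower number from compound 2 to compound 4 (1.76 log units; beyond the scatter) as the two large drops. Yet the same change made on the acid gives only a modest rise, a 4.3-fold higher number from compound 1 to compound 4 (0.64 log units; beyond the scatter) and this step is far smaller than either step from compound 1 to an amide, so leaving the carboxy group does not by itself bring a large rise among these four compounds, although compound 1 still has the lowest number. Nothing available here explains why the 4-hydroxybutyl chain stays so much closer to the acid than the two amide chains do.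

From the compounds shown here alone, whether the hydroxyl at the chain end is what keeps the number low remains open, and a plain methyl end or a methyl ether at this position would test that. An amine at the chain end and a longer chain ending in hydroxyl also remain open, so the compounds shown cannot yet say how far this result extends.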